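Nitro substitution on the triazole phenyl of a cinnamic acid series

A few compounds are considered here, and "the series" means these few. Any claim that something is new, unique, unknown or untested is made for them only; others in the source may bear on it.

Among the measured compounds shown here, compound 1 `COc1ccc(/C=C\C(=O)O)c(OCc2cn(-c3ccccc3)nn2)c1CC=C(C)C` carries the only number so far: in a functional assay on COLO 205 cells (Homo sapiens) for cytotoxicity, read by MTT assay, with a stated time of 24 h (a lower number here means a stronger inhibitor, a higher number a weaker inhibitor), compound 1 gives 32300 nM. Compound 2 `COc1ccc(-n2cc(COc3c(/C=C\C(=O)O)ccc(OC)c3CC=C(C)C)nn2)cc1` returns "not determined" (no result reported) in this assay, so no comparison is possible there. Compound 3 `COc1ccc(/C=C\C(=O)O)c(OCc2cn(-c3cccc([N+](=O)[O-])c3)nn2)c1CC=C(C)C` differs from compound 1 by nitro in place of hydrogen on an aromatic carbon. For the measured compounds named here, no step between measured compounds covers this change, so the expectation rests on compound 1 alone: a step of little size is expected, likely none beyond the scatter, in either direction. Compound 3 is therefore estimated at 25000 nM in this assay, within 8000 nM to 80000 nM, the expected step being a 1.3-fold lower number from compound 1 to compound 3 (0.11 log units; within the scatter).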

Compound 3, half-maximal inhibitory concentration: 6900 nM
Compound 3: middle estimate off by 3.6-fold (0.56 log units), on the high side; the measured number lies below the stated range.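

In this assay, the phenyl to 3-nitrophenyl change gives a 4.7-fold lower number from compound 1 to compound 3 (0.67 log units; beyond the scatter), so this place on the aromatic ring is not silent: a substituent here can move the read-out, which a single value could not show. Nothing available explains the origin of this step. On these data alone, it remains open whether the step belongs to nitro itself or would recur with another group at this place, such as an amine or a nitrile. As far as these compounds go, how nitro would read elsewhere on the same ring also remains open.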